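The source may hold more compounds than are shown below. What is called first, only, known or untested is meant among the compounds shown, and "the series" means these compounds.

Working notes on the series. Compound 1 `COc1cc(C(=O)O)ccc1OCCCCOc1ccc(C(=O)CC(C)(C)C)c(O)c1C` is the reference point: in an assay on HEK293 cells for positive allosteric modulation of metabotropic glutamate receptor 2 (Rattus norvegicus), read by thallium flux, with a stated time of 2.5 min (on this read-out higher numbers stand for an effect only at larger amounts of compound and lower numbers for an effect already at smaller amounts), compound 1 gives 47 nM. Compound 3 `Cc1c(OCCCCOc2cccc(C(=O)O)c2)ccc(C(=O)CC(C)C)c1O` keeps the 3-carboxyphenyl end and in this assay compound 3 gives 222 nM. Among the measured compounds shown here, compound 2 `Cc1c(OCCCCOc2cccc(C(=O)O)c2)ccc(C(=O)CC(C)C)c1C` differs from compound 3 only at the shared core and in this assay compound 2 gives "not active" (no number reported), so no single number stands for compound 2; it can only be placed as weaker than both compound 1 and compound 3, with no step of known size to either.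

Compound 4 `Cc1c(OCCCCOc2ccc(C(=O)O)c(Cl)c2)ccc(C(=O)CC(C)C)c1C` is the untested member. Relative to compound 2 the change is 4-carboxy-3-chlorophenyl in place of 3-carboxyphenyl on an oxygen on a saturated carbon. For the measured compounds named here, the 4-carboxy arrangement recalls compound 1, but compound 1 also carries a different core, so no measured pair isolates this change. With compound 2 lacking a number, the size and direction of the step in this assay cannot be read from the data; an improvement is plausible but unproven. Compound 4 is expected to give roughly 3000 nM, in a range of 400 nM to 20000 nM, with a real chance of again only a non-active report.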

Compound 4, half-maximal effective concentration: > 10000 nM
Compound 4 was reported as a limit; the forecaster's own chance of this, stated with the estimate: 50%; middle value at least 3.3-fold (0.52 log units) from the limit.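

Compound 4 gives [ > 10000 nM ], which is a limit and not a number. Among the compounds shown here, compound 2 has no number either, so no step between compound 2 and compound 4 can be read. The compounds shown leave open whether 4-carboxy-3-chlorophenyl in place of 3-carboxyphenyl changes the read-out at all.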